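The source may hold more compounds than are shown below. What is called first, only, known or untested is meant among the compounds shown, and "the series" means these compounds.

Compound 1 `COc1cc(OC)c(OC)cc1/C=C/C(=O)c1cc(Cl)ccc1O` was tested in a functional assay on MCF7 cells (Homo sapiens) for inhibition, read by MTT assay, with a stated time of 72 h; a higher number here means a weaker inhibitor, a lower number a stronger inhibitor. In this assay compound 1 reaches only a limit, > 150000 nM, so no number of its own is known for it, (the limit of > 150000 nM in this assay, at which 1 of the 3 values shown sits). Two other compounds were measured in this assay: compound 2 `COc1cc(OC)c(C(=O)/C=C/c2cc(OC)c(OC)cc2OC)c(OC)c1` gives 51400 nM, and compound 3 `COc1cc(C(=O)/C=C/c2cc(OC)c(OC)cc2OC)ccc1O` gives 95500 nM. Compound 1 therefore stands at the weak end of what has been measured, without a value that could be compared in size to the other two. The step to compound 4 `COc1cc(OC)c(OC)cc1/C=C/C(=O)c1cc(O)ccc1O` alters a single group: hydroxy in place of chloro on an aromatic carbon. For the measured compounds named here, no step between two measured compounds matches this change, so its size cannot be read from the data. The step from compound 1 to compound 4 is expected to be small, staying within the scatter or at most a modest gain, an at least 1.2-fold lower number from compound 1 to compound 4 (0.09 log units; that floor lies within the scatter). Compound 4 is estimated at 120000 nM in this assay, with a likely range from 40000 nM to 300000 nM, and a fair chance that the assay again reports only a limit.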

Compound 4, half-maximal inhibitory concentration: > 150000 nM
Compound 4 ended at the assay's limit; the forecaster's own chance of this, stated with the estimate: 50%; at least 1.2-fold (0.09 log units) between middle value and limit.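

Compound 1 and compound 4 both end at a limit in this assay, so no step between them can be read: the limit of > 150000 nM in this assay, at which 2 of the 4 values shown sit.

The compounds shown leave open whether hydroxy in place of chloro on an aromatic carbon changes the inhibition at all, and by how much.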